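Working notes: a pending hydroxyphenyl analogue in a small series

This account rests on a few compounds, and the source may have more. Where it says the series, first, only, none or still open, it means among the compounds named here.

Measured so far:
compound 1 `Cc1ccc(CS/C(=C/c2ccccc2F)C(=O)c2ccc(Cl)cc2)cc1`: 10000 nM
compound 2 `O=C(/C(=C\c1ccc(O)cc1O)SCc1ccc(Cl)cc1)c1ccc(Cl)cc1`: 50000 nM

In a functional assay on DU-145 cells (Homo sapiens) for inhibition, read by trypan blue exclusion, with a stated time of 96 h (on this read-out higher numbers stand for weaker inhibition of growth and lower numbers for stronger inhibition of growth), compound 1 gives 10000 nM, the lowest of the two numbers. Among the compounds with values here, compound 2 gives 50000 nM, a higher number beyond the scatter, but compound 2 differs from compound 1 in more than one place, so no single step is set between them. Compound 3 `Cc1ccc(CS/C(=C/c2ccc(O)c(O)c2O)C(=O)c2ccc(Cl)cc2)cc1` is not yet measured; against compound 1 the change is 2,3,4-trihydroxyphenyl in place of 2-fluorophenyl on a double-bonded chain carbon bound to a double-bonded chain carbon. Compound 2, the only measured case with hydroxyls on that ring, gives the weaker number, so a shift toward weaker inhibition or none beyond the scatter is expected. The expected step is a 2.0-fold higher number from compound 1 to compound 3 (0.30 log units; within the scatter). Compound 3 is estimated at 20000 nM, with a range from 7000 nM to 60000 nM.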

Compound 3, concentration for 50% growth inhibition: 50000 nM
Beside the measured number, compound 3's estimate is 2.5-fold (0.40 log units) below it; the measured number falls inside the stated range.
By their numbers in this assay, from the lowest: compound 1; then compounds 2 and 3 (each within the scatter of the next).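

Within the data shown here, this is the first single-place step: 2,3,4-trihydroxyphenyl in place of 2-fluorophenyl on a double-bonded chain carbon bound to a double-bonded chain carbon gives a 5.0-fold higher number from compound 1 to compound 3 (0.70 log units; beyond the scatter) in this assay, so the number at this place depends on the ring carried there. No evidence on hand bears on the reason for this step. The compounds shown leave open whether the departing fluorine or the entering hydroxyls set the step; both change at once. From the compounds shown here alone, how an unsubstituted phenyl or an aminophenyl would read at this place also stays open.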